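This account rests on a few compounds, and the source may have more. Where it says the series, first, only, none or still open, it means among the compounds named here.

Compound 1 `CC1(C)C=C(n2ccccc2=O)c2cc(C(=O)c3ccco3)ccc2O1` gives the higher of the two numbers measured in a functional assay (aorta) with Rattus norvegicus as the target (a higher number here means a more potent compound, by a factor of ten per unit of this negative logarithm, a lower number a less potent compound), at 6.49; compound 2 `CC1(C)C=C(n2ccccc2=O)c2cc(C(=O)c3ccccc3[N+](=O)[O-])ccc2O1` gives 6.17, the step of a number 0.32 log units lower from compound 1 to compound 2 (beyond the scatter). Compound 3 `Cc1ccc(C)n1-c1ccc2c(c1)C(n1ccccc1=O)=CC(C)(C)O2` differs from compound 1 in a single place (2,5-dimethyl-1H-pyrrol-1-yl in place of (furan-2-yl)carbonyl on an aromatic carbon). Within the data shown here, the only measured step, from compound 1 to compound 2, swaps one ring on the carbonyl for another and was modest; the change to compound 3 also removes the carbonyl itself, so its bearing is loose. A somewhat larger fall, a number 0.49 log units lower from compound 1 to compound 3 (beyond the scatter), is expected. Compound 3 is estimated at 6, within 5.4 to 6.6.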

Compound 3, logarithm of the reciprocal of the active concentration, log(1/C): 7.27
Compound 3: the middle estimate sits 1.27 log units below what was measured, outside the stated range (above it).
By their numbers in this assay, from the lowest: compound 2; then compound 1; then compound 3.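

Compound 1's carbonyl is not needed for a high number at this position: replacing (furan-2-yl)carbonyl with 2,5-dimethyl-1H-pyrrol-1-yl on the aromatic carbon gives a number 0.78 log units higher from compound 1 to compound 3 (beyond the scatter) in this assay. Both groups carry a five-membered aromatic ring with 1 hetero atom, so the ring type stays while the link to the core changes. No evidence is available to explain this rise. As far as these compounds go, whether it comes from the methyl groups, the ring's attachment through nitrogen or the loss of the carbonyl stays open, as does how an amine or a carboxylic acid would read on this aromatic carbon.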